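Bromo to Methyl in Two Pairs, One Measured

The source may hold more compounds than are shown below. What is called first, only, known or untested is meant among the compounds shown, and "the series" means these compounds.

Compound 1 `COc1ccc(CN(C(=O)CSC(=S)N2CCN(C(=O)OC(C)(C)C)CC2)c2ccc(Br)cc2)cc1` — > 20000 nM
Compound 2 `COc1ccc(CN(C(=O)CSC(=S)N2CCN(C(=O)OC(C)(C)C)CC2)c2ccc(C)cc2)cc1` — > 20000 nM
Compound 3 `COc1cc(N(Cc2ccc(Br)cc2)C(=O)CSC(=S)N2CCN(C(=O)OC(C)(C)C)CC2)cc(OC)c1OC` — 10700 nM

In a functional assay on KYSE-450 cells (Homo sapiens) for inhibition, read by CCK-8 assay, with a stated time of 48 h (a higher number here means a weaker inhibitor, a lower number a stronger inhibitor), compound 1 gives > 20000 nM, which is a limit of the assay and not a number. Compound 2 likewise gives > 20000 nM, again a limit. The two differ by methyl in place of bromo on an aromatic carbon, and the step that the two limits leave unreadable from compound 1 to compound 2 cannot be read, because the limit of > 20000 nM in this assay, at which 2 of the 3 values shown sit, hides both ends of it. Compound 3 is the only one of the three with a number: in this assay compound 3 gives 10700 nM. How the core of compound 3 differs from the core of compound 1 is not broken down here.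

Compound 4 `COc1cc(N(Cc2ccc(C)cc2)C(=O)CSC(=S)N2CCN(C(=O)OC(C)(C)C)CC2)cc(OC)c1OC` is not yet measured. Among the measured compounds shown here, it differs from compound 3 by methyl in place of bromo on an aromatic carbon, the same change as the one from compound 1 to compound 2, at a place described in the same words. Since that earlier step left no readable size, the expectation for compound 4 is a step of a 1.1-fold higher number from compound 3 to compound 4 (0.05 log units; within the scatter) that stays within the usual scatter, resting on compound 3 and its value 10700 nM as the only anchor. For compound 4 the estimated value is 12000 nM, expected to fall between 5000 nM and 30000 nM.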

Compound 4, half-maximal inhibitory concentration: > 20000 nM
Compound 4: no number, only a limit (the forecaster's own chance of this, stated with the estimate: 35%); middle value at least 1.6-fold (0.22 log units) away from the limit.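

In this assay compound 4 gives > 20000 nM, which is a limit of the assay and not a number. Methyl in place of bromo on the core of compound 3 therefore reads as an at least 1.8-fold higher number from compound 3 to compound 4 (0.27 log units; that floor lies within the scatter), which gives a floor and not a size, and that floor alone does not set compound 4 apart from compound 3 beyond the scatter. The same change on the core of compound 1 cannot be read, so this single step has no measured partner, and the data neither show that the change carries from one core to the other nor show that it fails to, because the comparison runs into one ceiling: the limit of > 20000 nM in this assay, at which 3 of the 4 values shown sit.

What the compounds shown leave open is whether a chloro group, an amine or a carboxylic acid in place of bromo on the core of compound 3 would keep a readable number in this assay. Also open is how such groups, or a longer chain such as ethyl, would read on the core of compound 1, where neither of the two compounds shown gives a number.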